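The source may report more compounds than this note shows. Statements on the series, on what has been measured and on what is new or still open speak of the compounds shown alone.

Of the compounds shown here, three have been measured in a functional assay on PC-9 cells (Homo sapiens) for inhibition, read by MTT assay, with a stated time of 48 h, tested at 10 uM; a lower number here means less inhibition, a higher number more inhibition at the concentration tested (going by the name of the read-out). Compound 1 `Cc1ccc(Nc2cc(NC(=O)Nc3c(Cl)cccc3Cl)ncn2)cc1F` gives 92% in this assay, and compound 3 `Cc1ccc(Nc2cc(NC(=O)Nc3c(Cl)cccc3Cl)ncn2)cc1C` gives 92.1%. The two differ only by a methyl in place of a fluoro on an aromatic carbon, and that change gave a number 0.1 percentage points higher from compound 1 to compound 3 (within the scatter). Compound 2 `CCc1cccc(Nc2cc(NC(=O)Nc3cc(OC)cc(OC)c3)ncn2)c1` gives 82.1% in this assay; this is the smallest of the three numbers, yet its gaps to compound 1 and to compound 3 both lie within the usual scatter, so the three cannot be told apart on these data.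

Compound 4 `CCc1ccc(Nc2cc(NC(=O)Nc3cc(OC)cc(OC)c3)ncn2)cc1` has not yet been measured. It differs from compound 2 in one place: 4-ethylphenyl in place of 3-ethylphenyl on a nitrogen on an aromatic ring. Among the measured compounds shown here, the only measured step, that from compound 1 to compound 3, concerns a different part of the shared core and lies within the scatter, so it offers no guide to moving the ethyl group on the phenyl ring. For the measured compounds named here, nothing measured so far bears directly on this change. The expectation is therefore a step of a number 0.1 percentage points lower from compound 2 to compound 4 (within the scatter) in this assay, which is no change beyond the scatter. Compound 4 is estimated to give 82% in this assay, with a range from 68% to 94%.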

Compound 4, a percentage reported as inhibition, at one concentration (the size of the read-out at that concentration, not a potency): 78%
For compound 4 the middle estimate is 4 percentage points above the measured one; measured number inside the range.
By their numbers in this assay, from the lowest: compounds 4, 2, 1 and 3 (each within the scatter of the next, the first and the last beyond it).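

In this assay, among the compounds shown here, putting 4-ethylphenyl in place of 3-ethylphenyl on the nitrogen gave a number 4.1 percentage points lower from compound 2 to compound 4 (within the scatter), the first measured step at this group, as the only earlier step was a methyl in place of a fluoro elsewhere on the molecule. For this one pair, then, moving the ethyl group around the phenyl ring brings no change that can be told from ordinary repeat-to-repeat variation, and inhibition stays high with the ethyl group in either place. Since each number comes from a single concentration and is not a potency, this does not rule out a difference that would show at lower concentrations, and no other measurement is available that could account for the step or its size.

On these data alone, it remains open whether a different group on this phenyl ring, such as an amine, a carboxylic acid or a longer chain like butyl, would produce a step beyond the scatter. It is also unknown whether the same shift of the ethyl group would behave alike when the rest of the molecule is that of compound 1.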